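The source may report more compounds than this note shows. Statements on the series, on what has been measured and on what is new or still open speak of the compounds shown alone.

Measured in a functional assay on MCF7 cells (Homo sapiens) for antiproliferative activity, read by sulforhodamine B assay, with a stated time of 48 h (a higher number here means a weaker inhibitor, a lower number a stronger inhibitor), so far:
- compound 1 `O=C1NCCN1c1ccc(S(=O)(=O)Nc2ccc(I)cc2)cc1` at 600 nM 
- compound 2 `O=C1NCCN1c1ccc(S(=O)(=O)Nc2cccc(Cl)c2)cc1` at 79 nM 

Compound 2 holds the lower of the two numbers. Compound 3 `Cc1ccccc1NS(=O)(=O)c1ccc(N2CCNC2=O)cc1` differs from it by 2-methylphenyl in place of 3-chlorophenyl on a sulfonamide nitrogen. Among the compounds with values here, the one measured step at this place is a 7.6-fold lower number from compound 1 to compound 2 (0.88 log units; beyond the scatter) and it lies beyond the scatter, so a change here can move the number, though that step gives no direction for this group. A modest move to a higher number in this assay is expected, estimated as a 2.5-fold higher number from compound 2 to compound 3 (0.40 log units; beyond the scatter) with wide uncertainty. Compound 3 is estimated at 200 nM (range 50 nM to 800 nM).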

Compound 3, half-maximal inhibitory concentration: 280 nM
Compound 3: middle estimate off by 1.4-fold (0.15 log units), on the low side, and the stated range covers the measured number.
By their numbers in this assay, from the lowest: compound 2; then compound 3; then compound 1.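

Notes on the group on the sulfonamide nitrogen in this assay: 2-methylphenyl gives a 3.5-fold higher number from compound 2 to compound 3 (0.55 log units; beyond the scatter), and against 4-iodophenyl it gives a 2.1-fold lower number from compound 1 to compound 3 (0.33 log units; beyond the scatter), so all three groups now stand apart, in the order compound 2, compound 3, compound 1. Since 2-methylphenyl differs from 3-chlorophenyl in both the substituent and its printed ring position, the step cannot assign the change to either. Nothing available explains these steps.

Still open, as far as these compounds go, is whether 3-methylphenyl or 2-chlorophenyl would separate those two changes. Also open, from the compounds shown here alone, is how an amine or a carboxylic acid on this ring would read.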